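Removing the carboxy group from an ester-linked selenium quinoline

The source may hold more compounds than are shown below. What is called first, only, known or untested is meant among the compounds shown, and "the series" means these compounds.

Compound 1, `CSc1cnc2ccccc2c1[Se]CC#CCOC(=O)c1ccc(C(=O)O)cc1`, has been tested in a functional assay on SW707 cells (Homo sapiens) for antiproliferative activity, with a stated time of 72 h (on this read-out lower numbers stand for stronger inhibition and higher numbers for weaker inhibition), where compound 1 gives 3.7 ug/mL. This is the higher of the two numbers recorded so far. The other measured compound, compound 2, `C#CCSc1cnc2ccccc2c1[Se]CC#CCCl`, gives 3.2 ug/mL in this assay, a gap that lies within the scatter of repeated measurements, so no order can be read between the two.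

The unmeasured compound 3, `CSc1cnc2ccccc2c1[Se]CC#CCOC(=O)c1ccccc1`, differs from compound 1 in one place: hydrogen in place of carboxy on an aromatic carbon. Within the data shown here, no pair of measured compounds shares this change, so there is no recorded step to lean on. The step from compound 1 to compound 3 is expected to be small, a 1.2-fold lower number from compound 1 to compound 3 (0.09 log units; within the scatter), and to stay within the usual scatter. Compound 3 is therefore estimated at 3 ug/mL in this assay, with a likely range from 1.2 ug/mL to 8 ug/mL.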

Compound 3, concentration for 50% inhibition: 3.6 ug/mL
Estimate against measurement, compound 3: 1.2-fold (0.08 log units) below; the range from low to high includes it.
By their numbers in this assay, from the lowest: compounds 2, 3 and 1 (each within the scatter of the next).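

The exchange of 4-carboxyphenyl to phenyl gives the first step recorded at this position, a 1.0-fold lower number from compound 1 to compound 3 (0.01 log units; within the scatter), in this assay. For this pair, then, the carboxy group on the aromatic carbon para to a large group can give way to hydrogen with no change beyond the scatter, and the read-out gives no sign that this group matters here. No measurement available here accounts for this result.

The compounds shown leave open whether an amine or a nitrile on the same aromatic carbon would also stay within the scatter of compound 3. They also leave open whether the phenyl ring of the ester could be replaced by a plain methyl group, or by a longer chain, with as little change.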